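This account rests on a few compounds, and the source may have more. Where it says the series, first, only, none or still open, it means among the compounds named here.

Working notes on the series. In an ADME assay on L02 cells (Homo sapiens) for inhibition, read by CCK-8 assay, with a stated time of 48 h (a lower number here means a stronger inhibitor of growth, a higher number a weaker inhibitor of growth), compound 1 `Cc1ccccc1Nc1nc(NC2CCCCC2)ncc1Cl` gives only a limit, > 100000 nM. Two compounds in the series give numbers. Compound 2 `Cc1ccccc1Nc1nc(Nc2ccc(N3CCNCC3)cn2)ncc1Cl` stands at 1850 nM. Compound 3 `COc1cccc(CNc2nc(Nc3ccc(N4CCN(C)CC4)cn3)ncc2Cl)c1` stands at 16200 nM, the higher of these two numbers, and the gap to compound 2 lies beyond the usual scatter. Compound 3 is therefore the weaker inhibitor of growth of the pair in this assay.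

The next compound is compound 4 `CC(C)c1cccc(Nc2nc(Nc3ccc(N4CCN(C)CC4)cn3)ncc2Cl)c1`, which has 3-isopropylphenyl in place of 3-methoxybenzyl on a nitrogen on an aromatic ring. The same difference can be read as (3-methoxybenzyl)amino to (3-isopropylphenyl)amino. Among the measured compounds shown here, no measured pair isolates this change, so the expectation rests on one indirect comparison. Compound 2, at 1850 nM, also carries a substituted phenyl rather than a benzyl on that nitrogen, though it differs from compound 4 elsewhere as well. This supports a move toward compound 2, but only part of the way.

A moderate step of a 2.7-fold lower number from compound 3 to compound 4 (0.43 log units; beyond the scatter) is expected, toward a lower number and slightly beyond the scatter. For compound 4 the estimated value in this assay is 6000 nM, with an expected range of 1800 nM to 18000 nM.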

Compound 4, concentration for 50% growth inhibition: 12500 nM
The estimate for compound 4 lay 2.1-fold (0.32 log units) below the measured number; the measured number falls inside the stated range.
By their numbers in this assay, from the lowest: compound 2; then compounds 4 and 3 (each within the scatter of the next). At a limit, above all of these: compound 1.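

In this assay, among the compounds shown here, the first direct reading at this position is a 1.3-fold lower number from compound 3 to compound 4 (0.11 log units; within the scatter), with 3-isopropylphenyl in place of 3-methoxybenzyl on a nitrogen on an aromatic ring. The exchange keeps the count of 9 heavy atoms and removes the single hydrogen-bond acceptor of the leaving group, yet the two compounds stay within the scatter of each other, so this pair shows no measurable difference in this assay for the change taken as a whole. Compounds 3 and 4 both give numbers, so the step can be read directly, whereas compound 1 alone gives a limit rather than a number: the limit of > 100000 nM in this assay, at which 1 of the 4 values shown sits.

The exchange alters the group on the nitrogen in two ways at once, from benzyl to phenyl and from methoxy to isopropyl, and this single pair cannot separate the two, which a benzyl carrying isopropyl or a phenyl carrying methoxy would begin to do. Going by these compounds, how this position responds to a charged or more strongly hydrogen-bonding group, such as a carboxylic acid or a primary amine on that ring, also remains open.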